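A Smaller Aromatic Ring on a Weakly Active Nucleoside

The source may report more compounds than this note shows. Statements on the series, on what has been measured and on what is new or still open speak of the compounds shown alone.

Compound 1 `COc1nc(N)nc2c1c(-c1cc3ccccc3o1)cn2[C@@H]1O[C@H](CO)[C@@H](O)[C@H]1O` was tested in a functional assay on HeLa S3 cells (Homo sapiens) for antiproliferative activity, read by XTT assay, with a stated time of 72 h; a higher number here means a weaker inhibitor, a lower number a stronger inhibitor. In this assay compound 1 gives > 20000 nM, which is a limit of the assay rather than a number; it stands at the limit of > 20000 nM in this assay, at which 2 of the 3 values shown sit. Compound 2 `Nc1nc(N)c2c(-c3cc4ccccc4o3)cn([C@@H]3O[C@H](CO)[C@@H](O)[C@H]3O)c2n1` carries amino in place of methoxy on an aromatic carbon. In this assay compound 2 gives > 20000 nM, again a limit of the assay. That makes a step that the two limits leave unreadable from compound 1 to compound 2. Compound 3 `COc1ncnc2c1c(-c1cc3ccccc3o1)cn2[C@@H]1O[C@H](CO)[C@@H](O)[C@H]1O` carries hydrogen in place of amino on an aromatic carbon, and in this assay compound 3 gives 9240 nM; that is an at least 2.1-fold lower number from compound 1 to compound 3 (0.33 log units; beyond the scatter).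

Compound 4 `COc1nc(N)nc2c1c(-c1cccs1)cn2[C@@H]1O[C@H](CO)[C@@H](O)[C@H]1O` differs from compound 1 in another place: thiophen-2-yl in place of 1-benzofuran-2-yl on an aromatic carbon. Neither measured step touches this part of the shared core, so neither bears on it, and no step beyond the scatter is expected in this assay in either direction. Because compound 1 already stands at the limit of > 20000 nM in this assay, at which 2 of the 3 values shown sit, compound 4 is expected to give about 25000 nM, within a range from 8000 nM to 80000 nM, most likely again as a limit. That estimate means an expected step that the limit leaves unreadable from compound 1 to compound 4.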

Compound 4, half-maximal inhibitory concentration: > 20000 nM
Compound 4 ended at the assay's limit; the forecaster's own chance of this, stated with the estimate: 70%; the middle value is on the limit's open side.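

In this assay compound 4 gives > 20000 nM, again a limit of the assay. No step can be read between compound 1 and compound 4, as both values sit at a limit: the limit of > 20000 nM in this assay, at which 3 of the 4 values shown sit. As far as these compounds go, whether thiophen-2-yl and 1-benzofuran-2-yl differ in effect on this core remains open.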